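The compounds below may be only part of what the source reports. "The series", "measured", "known", "first", "only" and "open" are said of these compounds alone.

Measured compounds:
`Cc1ccc(NS(=O)(=O)c2ccc(N3CCNC3=O)cc2)cc1` compound 1: 610 nM
`CCc1cccc(NS(=O)(=O)c2ccc(N3CCNC3=O)cc2)c1` compound 2: 130 nM

In a functional assay on MCF7 cells (Homo sapiens) for antiproliferative activity, read by sulforhodamine B assay, with a stated time of 48 h (on this read-out lower numbers stand for stronger inhibition and higher numbers for weaker inhibition), compound 1 gives 610 nM, the higher of the two numbers; compound 2 gives 130 nM, and the change is a 4.7-fold lower number from compound 1 to compound 2 (0.67 log units; beyond the scatter). Compound 3 `O=C1NCCN1c1ccc(S(=O)(=O)Nc2ccc(OC(F)F)cc2)cc1` differs from compound 1 by difluoromethoxy in place of methyl on an aromatic carbon. Going by the values given here, the one measured step alters the sulfonamide aryl in another way, so no measured step bears directly on this change, and nothing here points in either direction. The expected step is a 1.2-fold lower number from compound 1 to compound 3 (0.09 log units; within the scatter), within the scatter. The estimate for compound 3 in this assay is 500 nM, range 150 nM to 1600 nM.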

Compound 3, half-maximal inhibitory concentration: 760 nM
Estimate against measurement, compound 3: 1.5-fold (0.18 log units) below; the measured number falls inside the stated range.
By their numbers in this assay, from the lowest: compound 2; then compounds 1 and 3 (each within the scatter of the next).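

At this place, on an aromatic carbon para to a large group, difluoromethoxy in place of methyl gives a 1.2-fold higher number from compound 1 to compound 3 (0.10 log units; within the scatter) in this assay. The larger group, which brings a hydrogen-bond acceptor, therefore leaves the number within the scatter of the methyl compound. Nothing available accounts for this result.

From the compounds shown here alone, whether an amine, a carboxylic acid or a longer chain at this place would also stay within the scatter remains open. The compounds shown also do not separate the ethyl group of compound 2 from its ring position.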